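Two methyl groups added to a hydroxyphenyl hydrazone

The compounds below may be only part of what the source reports. "The series", "measured", "known", "first", "only" and "open" are said of these compounds alone.

Three compounds share one core. Compound 1 `CN(C)CCn1cnnc1-c1cc(Oc2ccc(NC(=O)N/N=C/c3cccc(Cl)c3Cl)cc2F)ccn1`, in an ADME assay on WI-38 cells (Homo sapiens) for cytotoxicity, read by MTT assay, with a stated time of 72 h (a higher number here means a weaker inhibitor, a lower number a stronger inhibitor), gives 6130 nM. Within the data shown here, compound 2 `CN(C)CCn1cnnc1-c1cc(Oc2ccc(NC(=O)N/N=C/c3ccc(O)c(O)c3)cc2F)ccn1` has in this assay only the entry "not determined" (no result reported), and compound 3 `CN(C)CCn1cnnc1-c1cc(Oc2ccc(NC(=O)N/N=C/c3ccc(O)cc3)cc2F)ccn1` likewise has in this assay only the entry "not determined" (no result reported), so there is no number for compound 3 to stand on; the only number in the set belongs to compound 1.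

Compound 4 `Cc1cc(/C=N/NC(=O)Nc2ccc(Oc3ccnc(-c4nncn4CCN(C)C)c3)c(F)c2)cc(C)c1O` differs from compound 3 in one place: 4-hydroxy-3,5-dimethylphenyl in place of 4-hydroxyphenyl on a carbon with a double bond to nitrogen. Among the measured compounds shown here, with no pair of measured compounds to compare, the step from compound 3 to compound 4 in this assay is expected to stay within the scatter, in no clear direction. Compound 4 is therefore estimated to give about 6000 nM in this assay, within a range from 1500 nM to 25000 nM.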

Compound 4, half-maximal inhibitory concentration: 3610 nM
Beside the measured number, compound 4's estimate is 1.7-fold (0.22 log units) above it, and the stated range covers the measured number.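

This position now has its first readable step: in this assay, placing 4-hydroxy-3,5-dimethylphenyl where 2,3-dichlorophenyl stood gives a 1.7-fold lower number from compound 1 to compound 4 (0.23 log units; within the scatter) and so leaves the two compounds indistinguishable in this test. Steps involving compound 2 or compound 3 cannot be read, as neither has a number. No evidence is available to explain this result.

On these data alone, it remains open whether a phenyl group carrying an amine or a carboxylic acid at this position would give a similar number.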